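Amide nitrogen substitution and whole-animal inhibition in the fluoroindanylidene series

This account rests on a few compounds, and the source may have more. Where it says the series, first, only, none or still open, it means among the compounds named here.

Compound 1 `O=C(/C=C1\CCc2ccc(F)cc21)NCCO` gives 78% in a functional assay on the whole organism with Rattus norvegicus as the target, at a dose of 20 mg/kg by the oral route (a higher number here means more inhibition at the dose given (going by the name of the read-out), a lower number less inhibition), and compound 2 `CC(C)NC(=O)/C=C1\CCc2ccc(F)cc21` gives 71%; the two lie within the scatter of each other. Compound 3 `O=C(/C=C1\CCc2ccc(F)cc21)N1CCCC1` gives 18%, the lowest of the three numbers, with a gap to either neighbour beyond the scatter. Compound 4 `O=C(/C=C1\CCc2ccc(F)cc21)NC1CCC1` differs from compound 3 by cyclobutylamino in place of pyrrolidin-1-yl on a carbonyl carbon. Among the measured compounds shown here, the steps that bear on this change run the other way: a number 60 percentage points lower from compound 1 to compound 3 (beyond the scatter) and a number 53 percentage points lower from compound 2 to compound 3 (beyond the scatter), both large, each removing the amide hydrogen. Compound 4 restores that hydrogen with a group of the same size as the isopropyl of compound 2, so a large rise in this assay is expected, roughly a number 47 percentage points higher from compound 3 to compound 4 (beyond the scatter). Compound 4 is estimated at 65%, within 45% to 82%.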

Compound 4, a percentage reported as inhibition, in the whole organism at one dose (the size of the read-out at that dose, not a potency): 0%
For compound 4 the middle estimate is 65 percentage points above the measured one; measured number outside the range, below it.
By their numbers in this assay, from the lowest: compound 4; then compound 3; then compounds 2 and 1 (each within the scatter of the next).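

The amide hydrogen alone does not secure a high number in this assay: compound 4 has a hydrogen-bond donor that compound 3 lacks, yet the result is a number 18 percentage points lower from compound 3 to compound 4 (beyond the scatter). On the amide-type nitrogen, the cyclobutyl ring separates sharply from the open-chain groups, with a number 71 percentage points lower from compound 2 to compound 4 (beyond the scatter) and a number 78 percentage points lower from compound 1 to compound 4 (beyond the scatter). No measurement at hand accounts for this drop.

Open, on these data alone, is whether cyclopropyl or cyclopentyl on this nitrogen would track compound 4, and whether tert-butyl or a longer chain would track compound 2.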